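This account rests on a few compounds, and the source may have more. Where it says the series, first, only, none or still open, it means among the compounds named here.

Compound 1, `COc1ccc(C(O)CCN2CC=C(Cc3ccccc3)CC2)cc1`: 57%
Compound 2, `OC(CCN1CC=C(Cc2ccccc2)CC1)c1ccc(Cl)cc1`: 61%

In an assay on CHO cells for inhibition of sodium-dependent dopamine transporter (Homo sapiens), read by scintillation counting, with a stated time of 10 min, tested at 10 uM (on this read-out lower numbers stand for less inhibition and higher numbers for more inhibition at the one concentration tested (going by the name of the read-out)), compound 1 gives 57% and compound 2 gives 61%. Among the compounds with values here, on these two numbers compound 2 sits at the upper end, but the only step between them, a number 4 percentage points higher from compound 1 to compound 2 (within the scatter), lies within the scatter, so the two compounds cannot be told apart on this read-out.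

Compound 3, `OC(CCN1CC=C(Cc2ccccc2)CC1)c1ccc(F)cc1F`, has not yet been measured in this assay. It differs from compound 2 in one place: 2,4-difluorophenyl in place of 4-chlorophenyl on a saturated chain carbon bound to an oxygen on a saturated carbon and a saturated chain carbon. Within the data shown here, the one measured step that bears on this is a number 4 percentage points higher from compound 1 to compound 2 (within the scatter), a swap of one group for another on the same aromatic ring, and it made no difference beyond the scatter. Among the measured compounds shown here, compound 3 carries two fluorine atoms on that ring where compound 2 carries one chlorine; no measured pair covers a second substituent, so the picture is incomplete. The expectation for compound 3 is therefore a step of a number 4 percentage points lower from compound 2 to compound 3 (within the scatter), not beyond the scatter. Compound 3 is expected to give about 57%, most likely between 40% and 74%.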

Compound 3, a percentage reported as inhibition, at one concentration (the size of the read-out at that concentration, not a potency): 66%
Compound 3: middle estimate off by 9 percentage points, on the low side; the measured number falls inside the stated range.
By their numbers in this assay, from the lowest: compounds 1, 2 and 3 (each within the scatter of the next).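

In this assay, the step from the 4-chlorophenyl group to the 2,4-difluorophenyl group on the saturated chain carbon is a number 5 percentage points higher from compound 2 to compound 3 (within the scatter), and the step from the 4-methoxyphenyl group to the same group is a number 9 percentage points higher from compound 1 to compound 3 (within the scatter). The earlier pair compared only rings with a single substituent, whereas these steps show that a ring with two fluorine atoms also cannot be told apart from either of them on this read-out, so all three aromatic groups at this position sit within the scatter of one another. No accompanying measurement offers an explanation for this result.

The three compounds leave open whether this position would still give indistinguishable numbers with a very different group on the ring, such as an amine or a carboxylic acid, or with a plain unsubstituted phenyl ring. They also leave open what a carbonyl in place of the alcohol or a longer chain would do, since the rest of the shared core stays the same throughout and each number comes from a single concentration rather than a potency.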